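Ring-nitrogen methylation in a set of indolinone growth inhibitors

The compounds below may be only part of what the source reports. "The series", "measured", "known", "first", "only" and "open" are said of these compounds alone.

Measured compounds:
compound 1, `COc1cc2c(/C=C3/C(=O)Nc4ccc(Br)cc43)c(Cl)[nH]c2cc1C`: 2240 nM
compound 2, `COc1cc2c(/C=C3/C(=O)Nc4cc(Cl)ccc43)c(Cl)[nH]c2cc1C`: 220 nM
compound 3, `COc1cc2c(/C=C3/C(=O)Nc4ccc(Br)cc43)c(Cl)n(C)c2cc1C`: 1550 nM

In a functional assay on cells (Cancer cell lines, Homo sapiens) for inhibition, with a stated time of 48 h (a lower number here means a stronger inhibitor of growth, a higher number a weaker inhibitor of growth), compound 2 gives the lowest of the three numbers; compound 1 and compound 3 sit well above it. How the core of compound 2 differs from that of compound 1 is not broken down here. Compound 1 and compound 3 differ in one place, (methyl in place of hydrogen on an aromatic nitrogen), and this gave a 1.4-fold lower number from compound 1 to compound 3 (0.16 log units; within the scatter). Compound 4, `COc1cc2c(/C=C3/C(=O)Nc4cc(Cl)ccc43)c(Cl)n(C)c2cc1C`, has not yet been measured in this assay. It arises from compound 2 by the same change, (methyl in place of hydrogen on an aromatic nitrogen). Since the change made so little difference from compound 1 to compound 3, compound 4 is expected to show a 1.1-fold lower number from compound 2 to compound 4 (0.04 log units; within the scatter), staying close to the value of compound 2. The estimate for compound 4 in this assay is therefore 200 nM, with a likely range from 80 nM to 600 nM.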

Compound 4, concentration for 50% growth inhibition: 20 nM
Beside the measured number, compound 4's estimate is 10-fold (1.00 log units) above it; the measured number lies below the stated range.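

In this assay, methyl in place of hydrogen on an aromatic nitrogen gave an 11-fold lower number from compound 2 to compound 4 (1.04 log units; beyond the scatter), so the change was not small on this second core. Set beside its earlier outcome, the same change does not carry over from one core to the other with a single size: the same change on two cores in this assay, a 1.4-fold lower number (0.16 log units; within the scatter) from compound 1 to compound 3 and an 11-fold lower number (1.04 log units; beyond the scatter) from compound 2 to compound 4, 7.6-fold (0.88 log units) apart, beyond the scatter of two such steps. This shows that the size of the step differs between these two cores, but two pairs do not show which feature of the cores accounts for the gap or how the change would behave on any further core.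

The compounds shown leave open whether an ethyl group or a longer chain on the same nitrogen would give a step of similar size. They also leave open how an amine in place of the chloro group would alter that step.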